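Compound 3 and a Change in the Ester Acyl Chain

A few compounds are considered here, and "the series" means these few. Any claim that something is new, unique, unknown or untested is made for them only; others in the source may bear on it.

Among the measured compounds shown here, in a functional assay on HeLa cells (Homo sapiens) for cytotoxicity, read by MTT assay (a higher number here means a weaker inhibitor, a lower number a stronger inhibitor), compound 2 `CCCC(CC(=O)O[C@H](CC=C(C)C)C1=CC(=O)c2c(O)ccc(O)c2C1=O)OC(C)=O` gives 51200 nM, and compound 1 `CC(C)=CC[C@@H](OC(=O)c1ccco1)C1=CC(=O)c2c(O)ccc(O)c2C1=O` gives 80300 nM; the two sit within the scatter of each other, as a 1.6-fold lower number from compound 1 to compound 2 (0.20 log units; within the scatter) shows, so compound 2 has no separate standing among the numbers so far. Compound 3 `CCCCC(C)(O)CC(=O)O[C@H](CC=C(C)C)C1=CC(=O)c2c(O)ccc(O)c2C1=O` differs from compound 2 in one place: 1-hydroxy-1-methylpentyl in place of 1-acetoxybutyl on a saturated chain carbon bound to a carbonyl carbon. For the measured compounds named here, the only measured step concerned the same acyl position and stayed within the scatter, so no step beyond the scatter is expected here. Compound 3 is therefore estimated at 45000 nM, between 20000 nM and 100000 nM, an expected step of a 1.1-fold lower number from compound 2 to compound 3 (0.06 log units; within the scatter).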

Compound 3, half-maximal inhibitory concentration: 60600 nM
Estimate against measurement, compound 3: 1.3-fold (0.13 log units) below, within the range that was stated.
By their numbers in this assay, from the lowest: compounds 2, 3 and 1 (each within the scatter of the next).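

In this assay, the swap of 1-acetoxybutyl for 1-hydroxy-1-methylpentyl gives a 1.2-fold higher number from compound 2 to compound 3 (0.07 log units; within the scatter) and so leaves the number effectively unmoved. The comparison with the furan-2-yl ester gives a 1.3-fold lower number from compound 1 to compound 3 (0.12 log units; within the scatter) and likewise stays within the scatter, so three different acyl groups at this position now read alike. No measurement at hand accounts for this. As far as these compounds go, whether an amine or a carboxylic acid on this acyl chain would produce a step beyond the scatter remains open, as does the effect of any change to the shared core.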